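Phenethyl for furan-2-yl on a benzamido core

The compounds below may be only part of what the source reports. "The series", "measured", "known", "first", "only" and "open" are said of these compounds alone.

Three compounds have been examined in a functional assay on HT-29 cells (Homo sapiens) for cytotoxicity, read by sulforhodamine B assay, with a stated time of 2 days, tested at 100 uM; on this read-out lower numbers stand for less inhibition and higher numbers for more inhibition at the one concentration tested (going by the name of the read-out). Compound 1 `O=C(Nn1c(-c2cccc([N+](=O)[O-])c2)nc2c(-c3ccco3)n[nH]c2c1=O)c1cccnc1` gives 11.7%. Compound 2 `O=C(Nn1c(-c2cccc([N+](=O)[O-])c2)nc2c(CCc3ccccc3)n[nH]c2c1=O)c1cccnc1` differs from it by phenethyl in place of furan-2-yl on an aromatic carbon and gives 20.1%, a step of a number 8.4 percentage points higher from compound 1 to compound 2 (within the scatter). Compound 3 `O=C(Nn1c(-c2cccc([N+](=O)[O-])c2)nc2c(-c3ccco3)n[nH]c2c1=O)c1ccccc1` differs from compound 1 by phenyl in place of pyridin-3-yl on a carbonyl carbon, and compound 3 gives 21.2%, a step of a number 9.5 percentage points higher from compound 1 to compound 3 (within the scatter). Compound 4 `O=C(Nn1c(-c2cccc([N+](=O)[O-])c2)nc2c(CCc3ccccc3)n[nH]c2c1=O)c1ccccc1` has not been measured; it differs from compound 3 by phenethyl in place of furan-2-yl on an aromatic carbon, the same change as between compound 1 and compound 2, made on a core that differs by phenyl in place of pyridin-3-yl on a carbonyl carbon. The expected step from compound 3 to compound 4 in this assay is a number 6.8 percentage points higher from compound 3 to compound 4 (within the scatter), resting on the earlier step of a number 8.4 percentage points higher from compound 1 to compound 2 (within the scatter) and on the value of compound 3 of 21.2%. Compound 4 is therefore expected to give about 28%, between 15% and 42%.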

Compound 4, a percentage reported as inhibition, at one concentration (the size of the read-out at that concentration, not a potency): 89.7%
Compound 4: the middle estimate sits 61.7 percentage points below what was measured; the measured number lies above the stated range.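

In this assay, phenethyl in place of furan-2-yl did not carry over from one core to the other, giving a number 68.5 percentage points higher from compound 3 to compound 4 (beyond the scatter) once phenyl stood on the carbonyl carbon: the same change on two cores in this assay, a number 8.4 percentage points higher (within the scatter) from compound 1 to compound 2 and a number 68.5 percentage points higher (beyond the scatter) from compound 3 to compound 4, 60.1 percentage points apart, beyond the scatter of two such steps Read from the other side, phenyl in place of pyridin-3-yl gave a number 69.6 percentage points higher from compound 2 to compound 4 (beyond the scatter), so the two changes together did far more than either alone: the same change on two cores in this assay, a number 9.5 percentage points higher (within the scatter) from compound 1 to compound 3 and a number 69.6 percentage points higher (beyond the scatter) from compound 2 to compound 4, 60.1 percentage points apart, beyond the scatter of two such steps This shows that the step depends on the core in this set, but it rests on four compounds at one concentration and does not show why the two changes act together.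

On these data alone, it remains open whether a benzyl group or a longer chain in place of phenethyl would behave alike. The same holds for a pyridin-4-yl group in place of phenyl on the carbonyl carbon.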